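The source may hold more compounds than are shown below. What is called first, only, known or untested is meant among the compounds shown, and "the series" means these compounds.

Series notes, cytotoxicity on one cell line.

Compound 1 `CO/N=c1\[nH]cnc2c1[n+](C/C=C(\C)CC/C=C(/C)CCC=C(C)C)cn2C` is the reference point. In a functional assay on U-937/GTB cells (Homo sapiens) for cytotoxicity (a lower number here means a stronger inhibitor, a higher number a weaker inhibitor), compound 1 gives 1400 nM. Going by the values given here, compound 2 `CC(C)=CCC/C(C)=C\CC/C(C)=C/C[n+]1cn(C)c2nc[nH]/c(=N\OCc3ccccc3)c21` differs from compound 1 by phenyl in place of hydrogen on a saturated chain carbon bound to an oxygen; in this assay compound 2 gives 7550 nM, and the step of a 5.4-fold higher number from compound 1 to compound 2 (0.73 log units; beyond the scatter) is the one measured example of this change in the set.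

Compound 3 `CO/N=c1\[nH]cnc2c1[n+](C/C=C(\C)CCCC(C)CCCC(C)CCCC(C)C)cn2C` carries a different side chain on the same charged core; the difference between compound 3 and compound 1 is not broken down here. In this assay compound 3 gives 5400 nM, close to compound 2 and weaker than compound 1.

Compound 4 `C/C(=C\C[n+]1cn(C)c2nc[nH]/c(=N\OCc3ccccc3)c21)CCCC(C)CCCC(C)CCCC(C)C` has not been measured. It differs from compound 3 by phenyl in place of hydrogen on a saturated chain carbon bound to an oxygen, the same change, at the same place, as that from compound 1 to compound 2. Among the compounds with values here, because the earlier step was a 5.4-fold higher number from compound 1 to compound 2 (0.73 log units; beyond the scatter), the expected step for compound 4 is a 3.7-fold higher number from compound 3 to compound 4 (0.57 log units; beyond the scatter), a weakening of similar size, with wide uncertainty since only one pair supports it. Compound 4 is therefore estimated at 20000 nM in this assay, with a likely range of 7000 nM to 55000 nM.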

Compound 4, half-maximal inhibitory concentration: 10800 nM
Compound 4: the middle estimate sits 1.9-fold (0.27 log units) above what was measured; low and high end bracket the measured number.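

In this assay, methoxy to benzyloxy gives a 2.0-fold higher number from compound 3 to compound 4 (0.30 log units; within the scatter). Set beside the earlier step, the size of this change does not carry over unchanged from one core to the other: the same change on two cores in this assay, a 5.4-fold higher number (0.73 log units; beyond the scatter) from compound 1 to compound 2 and a 2.0-fold higher number (0.30 log units; within the scatter) from compound 3 to compound 4, 2.7-fold (0.43 log units) apart, beyond the scatter of two such steps. The second step alone cannot be told from the scatter, so a shared direction is not established, and two pairs give neither a rule for other cores nor an explanation of the gap.

Open, as far as these compounds go, is how other groups on this oxygen would behave, for example an ethyl group, a longer chain, or a benzyl group whose phenyl ring carries a fluorine or an amine, and whether any of them would follow either step. Also open, from the compounds shown here alone, is whether the size of the step follows the side chain in general, since only the two side chains of compound 1 and compound 3 bear on it here.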